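The compounds below may be only part of what the source reports. "The series", "measured", "known", "first", "only" and "open" are said of these compounds alone.

Working notes on the series. Two compounds have numbers in a functional assay on CHO cells for antagonist activity at metabotropic glutamate receptor 5 (Rattus norvegicus), read by calcium flux (a higher number here means a weaker inhibitor, a lower number a stronger inhibitor), so far. Compound 1 `Cc1ccc(-c2ccc3cccnc3n2)cc1C` gives 45 nM in this assay. Among the measured compounds shown here, compound 2 `Cc1cccc(-c2cc3ncccc3cn2)c1` gives 1270 nM in this assay, the higher of the two numbers by a margin beyond the scatter, so compound 2 is the weaker inhibitor of the pair; no one-place step connects it to compound 1, and nothing more is read into that gap.

Compound 3 `Cc1cccc(-c2cc3nc(C)ccc3cn2)c1` is not yet measured. It differs from compound 2 by a single change: methyl in place of hydrogen on an aromatic carbon. For the measured compounds named here, no step of this kind has been measured, so there is no observed precedent for the size or direction of its effect. The working expectation is a small change at most, not clearly beyond the scatter, perhaps a slight lowering of the number. For compound 3 the estimate in this assay is 900 nM, with a range of 300 nM to 3000 nM, which corresponds to an expected step of a 1.4-fold lower number from compound 2 to compound 3 (0.15 log units; within the scatter).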

Compound 3, half-maximal inhibitory concentration: 676 nM
Estimate against measurement, compound 3: 1.3-fold (0.12 log units) above; the measured number falls inside the stated range.
By their numbers in this assay, from the lowest: compound 1; then compounds 3 and 2 (each within the scatter of the next).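

In this assay, methyl in place of hydrogen on an aromatic carbon next to the ring nitrogen gives a 1.9-fold lower number from compound 2 to compound 3 (0.27 log units; within the scatter), so at this position the added methyl leaves no change that can be told from the scatter. Among the compounds shown here, this is the first step of its kind, and a single step at one position gives no size for the same change elsewhere on the core. Nothing available offers a reason for this step.

As far as these compounds go, whether a different group at this position, such as an ethyl, a methoxy, an amine or a carboxylic acid, would also stay within the scatter remains open. Also open, from the compounds shown here alone, is whether methyl on the other aromatic carbons of the shared core would behave as it does here.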